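A few compounds are considered here, and "the series" means these few. Any claim that something is new, unique, unknown or untested is made for them only; others in the source may bear on it.

Measured so far:
Compound 1, `Cc1c(Nc2nc(N)c3c(C#N)c(N4CCC[C@H]4C)n(C)c3n2)cnn1C`: 3 nM
Compound 2, `C[C@@H]1CCCN1c1c(C#N)c2c(N)ncnc2n1C`: 0.7 nM

In an assay on isolated protein for binding affinity to Leucine-rich repeat serine/threonine-protein kinase 2 variant G2019S (Homo sapiens), read by TR-FRET and LanthaScreen, with a stated time of 2 h (on this read-out higher numbers stand for weaker inhibition and lower numbers for stronger inhibition), compound 2 gives 0.7 nM, the lowest of the two numbers measured. Among the compounds with values here, its only neighbour is compound 1, which in this assay gives 3 nM. Within the data shown here, the single measured step, a 4.3-fold lower number from compound 1 to compound 2 (0.63 log units; beyond the scatter), is modest and lies beyond the scatter.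

Compound 3, `C[C@@H]1CCCN1c1cc2c(N)ncnc2n1C`, has not been measured. It differs from compound 2 by hydrogen in place of cyano on an aromatic carbon. Among the measured compounds shown here, no measured step touches the cyano group: the step from compound 1 to compound 2 removed a different group at a different position, so it offers no direct guide to what removing a nitrile will do. The expectation therefore rests on compound 2 alone, and on the general observation that stripping a substituent from a potent compound more often weakens than strengthens it, without any shown example here to confirm that.

On that basis compound 3 is expected to give a somewhat higher number, around 5 nM, with a wide range from 1 nM to 30 nM. The expected change in this assay is a 7.1-fold higher number from compound 2 to compound 3 (0.85 log units; beyond the scatter), an estimate with considerable uncertainty in both size and direction.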

Compound 3, inhibition constant: 439 nM
Compound 3: the middle estimate sits 88-fold (1.94 log units) below what was measured, outside the stated range (above it).
By their numbers in this assay, from the lowest: compound 2; then compound 1; then compound 3.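

In this assay, within the data shown here, the cyano group on this aromatic carbon proves to count for far more than the earlier compounds could show: replacing it with hydrogen gives a 630-fold higher number from compound 2 to compound 3 (2.80 log units; beyond the scatter), a large step. That step is much bigger than a 4.3-fold lower number from compound 1 to compound 2 (0.63 log units; beyond the scatter) and runs the other way, so taking a group off the shared core does not have one fixed outcome here, since the number fell in one case and rose in the other. The change itself is small, only two heavy atoms, one carbon and one nitrogen, yet nothing available explains why it has such an effect on the number.

At this carbon the compounds shown carry only cyano or hydrogen, so a methyl group, a chlorine atom or a carboxamide there would help show whether the nitrile itself matters or whether other small groups could serve as well. From the compounds shown here alone, it also stays open whether the same loss would follow with the (1,5-dimethyl-1H-pyrazol-4-yl)amino group present, as that group appears only in compound 1, which keeps its nitrile.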